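From Amino to Dimethylamino on a Shared Core

The source may report more compounds than this note shows. Statements on the series, on what has been measured and on what is new or still open speak of the compounds shown alone.

Compound 1 `CCOc1ccc(-c2nnc(SCc3ccc(Cl)nc3)o2)cc1`: 4.97 ug/mL
Compound 2 `Oc1ccc(-c2nnc(SCc3ccc(Cl)nc3)o2)cc1`: > 20 ug/mL
Compound 3 `Nc1ccc(-c2nnc(SCc3ccc(Cl)nc3)o2)cc1`: 8.48 ug/mL

These results come from a functional assay on SGC-7901 cells (Homo sapiens) for antiproliferative activity, read by MTT assay, with a stated time of 48 h; a lower number here means a stronger inhibitor, a higher number a weaker inhibitor. For compound 2, the reading of > 20 ug/mL is a limit of the assay and not a number. Compound 3, at 8.48 ug/mL, cannot be told apart from compound 1, as a 1.7-fold higher number from compound 1 to compound 3 (0.23 log units; within the scatter) shows.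

The next compound is compound 4 `CN(C)c1ccc(-c2nnc(SCc3ccc(Cl)nc3)o2)cc1`. It carries dimethylamino in place of amino on an aromatic carbon, para to a large group: dimethylamino in place of amino on an aromatic carbon.

Among the compounds with values here, no measured step changes the amino group itself, so the closest guide is a comparison on oxygen. Replacing the ethyl of the ethoxy group with hydrogen gave an at least 4.0-fold higher number from compound 1 to compound 2 (0.60 log units; beyond the scatter). Amino in place of hydroxy gave an at least 2.3-fold lower number from compound 2 to compound 3 (0.37 log units; beyond the scatter). Together, these steps suggest that the free hydroxy compound fares poorly in this assay, but this is a single comparison and it does not involve nitrogen. Replacing ethoxy with amino made no change beyond the scatter, so only a small shift toward a lower number is expected, with no step beyond the scatter. The expected change is a 1.4-fold lower number from compound 3 to compound 4 (0.15 log units; within the scatter). For compound 4, the estimated value is 6 ug/mL, with an expected range from 2.5 ug/mL to 14 ug/mL.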

Compound 4, half-maximal inhibitory concentration: 8.9 ug/mL
Estimate against measurement, compound 4: 1.5-fold (0.17 log units) below; the range from low to high includes it.
By their numbers in this assay, from the lowest: compounds 1, 3 and 4 (each within the scatter of the next). At a limit, above all of these: compound 2.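

In this assay, amino with 1 hydrogen-bond donor gives way to dimethylamino with 0 hydrogen-bond donors on an aromatic carbon, para to a large group, and the result is a 1.0-fold higher number from compound 3 to compound 4 (0.02 log units; within the scatter). For this pair, then, losing the donor and gaining 2 carbon atoms leaves no mark that can be told from the scatter, and dimethylamino also stays level with the ethoxy group, with a 1.8-fold higher number from compound 1 to compound 4 (0.25 log units; within the scatter), so compounds 1, 3 and 4 cannot be separated. Only the hydroxy group stands apart, with an at least 2.2-fold lower number from compound 2 to compound 4 (0.35 log units; beyond the scatter), and that step rests on a reading for compound 2 that is a limit of the assay and not a number: the limit of > 20 ug/mL in this assay, at which 1 of the 4 values shown sits.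

On these data alone, how a methylamino group, a carboxylic acid or a longer alkoxy chain would read at this same place remains open, and so does how far the tolerance seen here extends beyond these few groups. All of these readings also come from a single cell line, so whether compounds 1, 3 and 4 would stay level in other cells is an open question too.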